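Replacing a lactam with a trifluoromethyl pyrazole

This account rests on a few compounds, and the source may have more. Where it says the series, first, only, none or still open, it means among the compounds named here.

Of the compounds shown here, three have been measured so far. Compound 1 `Cc1ccc(C(=O)Nc2sc3c(c2C(N)=O)CCCC3)s1` gives 652 nM in an assay on cells for positive allosteric modulation of Cystic fibrosis transmembrane conductance regulator variant F508del (Homo sapiens), with stated times of 10 min and 7 s, in the presence of a further agent that is not named here; a higher number here means that more compound is needed for the effect, a lower number that less compound is needed. Compound 2 `CC1Cc2c(sc(NC(=O)c3ccccc3O)c2C(N)=O)C(C)O1` gives 4 nM in this assay. For compound 3 `CC1(C)Cc2c(sc(NC(=O)C3CNC(=O)C3)c2C(N)=O)C(C)(C)O1` only a limit is known in this assay, namely > 10000 nM, so its true value is not a number here; it sits at the limit of > 10000 nM in this assay, at which 1 of the 3 values shown sits.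

Compound 4 `CC1(C)Cc2c(sc(NC(=O)c3cc(C(F)(F)F)n[nH]3)c2C(N)=O)C(C)(C)O1` has not yet been measured. It differs from compound 3 in one place: 3-(trifluoromethyl)-1H-pyrazol-5-yl in place of 5-oxopyrrolidin-3-yl on a carbonyl carbon. Going by the values given here, no measured pair shows this change directly, so the expectation rests on the other compounds. Compound 4 is expected to need less compound than the limit seen for compound 3, with a step of an at least 33-fold lower number from compound 3 to compound 4 (1.52 log units; beyond the scatter). The estimate for compound 4 in this assay is 300 nM, within a range from 30 nM to 5000 nM.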

Compound 4, half-maximal effective concentration: 3 nM
Compound 4: the middle estimate sits 100-fold (2.00 log units) above what was measured, and the stated range ends above it.
By their numbers in this assay, from the lowest: compounds 4 and 2 (each within the scatter of the next); then compound 1. At a limit, above all of these: compound 3.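

On this carbonyl carbon, with the rest of the molecule held fixed, the choice of group decides whether there is any measurable effect in this assay: there is an at least 3300-fold lower number from compound 3 to compound 4 (3.52 log units; beyond the scatter). The two groups match in hydrogen-bond donors, hydrogen-bond acceptors and net charge, so those counts alone do not account for the gap. The true size of the step stays unknown, since compound 3 stands at a limit of the assay: the limit of > 10000 nM in this assay, at which 1 of the 4 values shown sits.

The compounds shown do not separate the pyrazole ring from its trifluoromethyl group. A pyrazole carrying a methyl group or a nitrile instead would test which of the two matters.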